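This account rests on a few compounds, and the source may have more. Where it says the series, first, only, none or still open, it means among the compounds named here.

In a functional assay on MCF7 cells (Homo sapiens) for inhibition, with a stated time of 72 h (a higher number here means a weaker inhibitor, a lower number a stronger inhibitor), three compounds share one core and differ only in what sits on an aromatic carbon of the six-membered aromatic ring of carbon only. Compound 1 `NC1CCC(Nc2nc(NCc3ccc(-c4ccccc4)cc3)c3ncn(C4CCCC4)c3n2)CC1` gives 583 nM. Compound 2 `COc1ccccc1-c1ccc(CNc2nc(NC3CCC(N)CC3)nc3c2ncn3C2CCCC2)cc1` gives 303 nM, and compound 3 `NC1CCC(Nc2nc(NCc3ccc(-c4cccc(F)c4)cc3)c3ncn(C4CCCC4)c3n2)CC1` gives 293 nM. The steps among them are a 1.9-fold lower number from compound 1 to compound 2 (0.28 log units; within the scatter), a 2.0-fold lower number from compound 1 to compound 3 (0.30 log units; within the scatter) and a 1.0-fold lower number from compound 2 to compound 3 (0.01 log units; within the scatter). Compound 3 thus holds the lowest of the three numbers, but its gaps to compound 2 and to compound 1 both lie within the scatter, so no order among the three can be claimed.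

Compound 4 `NC1CCC(Nc2nc(NCc3ccc(-n4cccn4)cc3)c3ncn(C4CCCC4)c3n2)CC1` has not yet been measured. It differs from compound 3 by 1H-pyrazol-1-yl in place of 3-fluorophenyl on an aromatic carbon. Going by the values given here, the steps that bear on this change are the three measured ones, each of which altered the same pendant group and each of which stayed within the scatter. None of them swapped a six-membered aromatic ring of carbon only for a five-membered aromatic ring with two hetero atoms, so they give only a loose guide, yet they point to at most a modest shift in either direction. Compound 4 is therefore expected to show a step of a 1.4-fold higher number from compound 3 to compound 4 (0.14 log units; within the scatter), with an estimated value of 400 nM in this assay, in a range from 150 nM to 1100 nM.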

Compound 4, half-maximal inhibitory concentration: 139 nM
Estimate against measurement, compound 4: 2.9-fold (0.46 log units) above, outside the stated range (below it).
By their numbers in this assay, from the lowest: compound 4; then compounds 3, 2 and 1 (each within the scatter of the next).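

In this assay, going by these compounds alone, this place on an aromatic carbon, para to a large group, now shows a change beyond the scatter, which none of the earlier steps had done: 1H-pyrazol-1-yl in place of 3-fluorophenyl gives a 2.1-fold lower number from compound 3 to compound 4 (0.32 log units; beyond the scatter), in place of 2-methoxyphenyl gives a 2.2-fold lower number from compound 2 to compound 4 (0.34 log units; beyond the scatter), and in place of phenyl gives a 4.2-fold lower number from compound 1 to compound 4 (0.62 log units; beyond the scatter). All three steps are modest, yet they set compound 4 apart as the strongest inhibitor of the four, whereas the three compounds with a six-membered aromatic ring of carbon only could not be ordered among themselves. The earlier steps shown here only varied a substituent on that ring, while this change replaces the ring itself with a five-membered aromatic ring with 2 hetero atoms and brings 2 hydrogen-bond acceptors where there were none.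

Ring size, the nitrogen atoms and the point of attachment all change together in this one compound, so a pyridine, an imidazole or a triazole in the same place would be needed to tell them apart. Nothing available here accounts for the size or the direction of the step.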